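Compound 2 to compound 4: from anilide to benzyl amide

A few compounds are considered here, and "the series" means these few. Any claim that something is new, unique, unknown or untested is made for them only; others in the source may bear on it.

In a functional assay on Huh-7 cells (Homo sapiens) for inhibition, read by MTT assay, with a stated time of 48 h (a lower number here means a stronger inhibitor, a higher number a weaker inhibitor), compound 2 `COc1ccc2c(=O)c(/C=C/C(=O)Nc3cc(C)ccc3C)coc2c1` gives 11100 nM, a higher number, beyond the scatter, than compound 1 `O=C(/C=C/c1coc2cc(O)ccc2c1=O)NCc1ccccc1` at 4690 nM. Compound 3 `O=C(/C=C/c1coc2cc(O)ccc2c1=O)NCc1ccc(F)cc1` reports only a limit, > 100000 nM.

Compound 4 `COc1ccc2c(=O)c(/C=C/C(=O)NCc3ccc(C)cc3)coc2c1` keeps the core of compound 2 and has 4-methylbenzyl in place of 2,5-dimethylphenyl on an amide-type nitrogen.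

For the measured compounds named here, no measured step makes this exchange. The nearest evidence is the large step of fluoro in place of hydrogen on an aromatic carbon, an at least 21-fold higher number from compound 1 to compound 3 (1.32 log units; beyond the scatter). Compound 1 and compound 3 both carry a benzyl group on the amide, as compound 4 does, though on a different core. That step shows that one substituent on such a benzyl ring can push the number up sharply, so a higher number is expected here, with wide uncertainty and a smaller size than that step.

The expected change is a 2.3-fold higher number from compound 2 to compound 4 (0.35 log units; beyond the scatter). In this assay, compound 4 is estimated at 25000 nM, with an expected range from 6000 nM to 100000 nM.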

Compound 4, half-maximal inhibitory concentration: 14300 nM
For compound 4 the middle estimate is 1.7-fold (0.24 log units) above the measured one, and the stated range covers the measured number.
By their numbers in this assay, from the lowest: compound 1; then compounds 2 and 4 (each within the scatter of the next). At a limit, above all of these: compound 3.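

In this assay, 4-methylbenzyl in place of 2,5-dimethylphenyl on an amide-type nitrogen gives a 1.3-fold higher number from compound 2 to compound 4 (0.11 log units; within the scatter) so on the core of compound 2 the two groups cannot be told apart. This is the first step shown at the amide nitrogen itself, since the earlier step changed only a substituent on a benzyl ring that stayed in place. The large step seen there therefore has no counterpart in this exchange, and nothing shown gives a cause for this result.

The compounds shown leave open whether the same exchange gives a similar result on the core of compound 1, and what fluoro on the benzyl ring does on the core of compound 4. They also leave open how a longer chain such as 2-phenylethyl, or a carboxylic acid on the ring, would read at this nitrogen.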